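The compounds below may be only part of what the source reports. "The series", "measured", "known", "first", "only" and "open" are said of these compounds alone.

Compound 1 `CC1(C[C@@H](O)C(=O)N2N=CC[C@H]2C(=O)NCc2cc(Cl)ccc2-n2cnnn2)CC1` was read in an ADME assay on liver for metabolic stability, with Liver microsome (Homo sapiens) as the target, read by LC-MS, using microsomes; on this read-out higher numbers stand for fast clearance and lower numbers for slow clearance. For compound 1 this assay returns only a limit, < 12 mL.min-1.g-1, and not a number. The same holds for compound 2 `CC(C)(C)C[C@@H](O)C(=O)N1OCC[C@H]1C(=O)NCc1cc(Cl)ccc1-n1cnnn1`, which gives the limit < 12 mL.min-1.g-1. Compound 3 `O=C(NCc1cc(Cl)ccc1-n1cnnn1)[C@@H]1[C@H]2C[C@H]2CN1C(=O)[C@H](O)c1ccccc1` is the one of the three with a measured number, 61 mL.min-1.g-1. Compound 1 thus sits where two of the three results sit, at the limit of < 12 mL.min-1.g-1 in this assay, at which 2 of the 3 values shown sit, and nothing finer than that is known of it.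

The step to compound 4 `CC(C)(C)C[C@@H](O)C(=O)N1N=CC[C@H]1C(=O)NCc1cc(Cl)ccc1-n1cnnn1` alters the side chain only: tert-butyl in place of 1-methylcyclopropyl on a saturated chain carbon, two bonds along the chain from a carbonyl carbon and an oxygen on a saturated carbon. Within the data shown here, no pair of measured compounds differs in just this place, so the size of the step cannot be read from a neighbour. Compound 2 carries the tert-butyl chain and returns the limit, and on that ground the step is expected to leave the read-out where compound 1 stands, with no change beyond the scatter of this assay. The estimated step is a step that the limit leaves unreadable from compound 1 to compound 4. Compound 4 is therefore expected to give 10 mL.min-1.g-1, between 5 mL.min-1.g-1 and 22 mL.min-1.g-1, and most probably the assay will again report only its limit.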

Compound 4, intrinsic clearance in microsomes: 22 mL.min-1.g-1
Compound 4: middle estimate off by 2.2-fold (0.34 log units), on the low side; the measured number falls inside the stated range.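

In this assay, tert-butyl in place of 1-methylcyclopropyl, on a saturated chain carbon, two bonds along the chain from a carbonyl carbon and an oxygen on a saturated carbon, gives an at least 1.8-fold higher number from compound 1 to compound 4 (0.26 log units; that floor lies within the scatter). Among these compounds, this is the first comparison at this position, and it shows that the change can bring the read-out to a number: compound 4 returns a value where compound 1 returns only a limit, though the floor of the step does not by itself separate the two compounds beyond the scatter. The step has a floor and no upper bound because the result for compound 1 is not a number: the limit of < 12 mL.min-1.g-1 in this assay, at which 2 of the 4 values shown sit.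

The compounds shown leave open how the read-out would respond at this position to other groups, such as cyclobutyl, a longer chain, or a chain carrying an amine or a carboxylic acid. They also leave open whether tert-butyl in place of 1-methylcyclopropyl would give a step of similar size on a core other than that of compound 1.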